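The compounds below may be only part of what the source reports. "The series", "measured", "known", "first", "only" and "open" are said of these compounds alone.

Of the compounds shown here, two have been measured in a physicochemical assay for acid dissociation. Compound 1, `Cc1cnc(NCC2(c3ccccc3)CCC2)c(=O)n1CC(=O)NCc1ccc2c(N)noc2c1`, gives 8.6 in this assay. Compound 2, `Cc1cc2cn[nH]c2cc1CNC(=O)Cn1c(C)ccc(NS(=O)(=O)Cc2ccccc2)c1=O`, gives 4. Among the compounds with values here, compound 1 thus holds the higher of the two numbers, and its only neighbour, compound 2, lies far lower, well beyond the scatter of this kind of measurement. The two differ in many places at once, so no single structural step can be read from them.

Compound 3, `Cc1cnc(NCC2(c3ccc(F)cc3)CC2)c(=O)n1CC(=O)NCc1ccc2c(N)noc2c1`, is not yet measured. Set beside compound 1, it differs in one place: 1-(4-fluorophenyl)cyclopropyl in place of 1-phenylcyclobutyl on a saturated chain carbon bound to a nitrogen on an aromatic ring. One ring-bearing group is exchanged for another, and the counted numbers of heavy atoms, donors and acceptors stay the same. Within the data shown here, no measured pair shows what such an exchange does here. A step from compound 1 to compound 3 of no more than the usual scatter is expected, in either direction, and the expected step is a number 0.10 log units lower from compound 1 to compound 3 (within the scatter). For compound 3 the estimated value in this assay is 8.5, with a range from 8.1 to 8.9.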

Compound 3, acid dissociation constant: 8.6
Estimate against measurement, compound 3: 0.10 log units below, and the stated range covers the measured number.
By their numbers in this assay, from the lowest: compound 2; then compounds 1 and 3 (each within the scatter of the next).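

In this assay, this position now has its first readable step: 1-(4-fluorophenyl)cyclopropyl in place of 1-phenylcyclobutyl gives no change at the digits printed from compound 1 to compound 3 (within the scatter). This single exchange swaps a four-membered ring of carbon for a three-membered one and also brings in a fluorine atom, while the number of heavy atoms stays the same, so the read-out at this place tolerates these two alterations made together. No measurement available here bears on why this is so.

The two alterations also remain tied together in the compounds shown, and they could have separate influences that happen to cancel: only 1-phenylcyclopropyl and 1-(4-fluorophenyl)cyclobutyl at this place, each carrying just one of the two alterations, could tell them apart. On these data alone, it also remains open whether the same holds for a group of another kind on the saturated chain carbon bound to a nitrogen on an aromatic ring, such as a 1-(4-aminophenyl)cyclopropyl group carrying an amine, or a group carrying a carboxylic acid.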